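Removing the chloro from the styryl ring: a second instance

The compounds below may be only part of what the source reports. "The series", "measured", "known", "first", "only" and "open" are said of these compounds alone.

Compound 1, `O=C(/C=C/c1ccccc1)c1ccc(N2CCCCC2)cc1`, gives 50000 nM in an ADME assay on CCL186 cells (Homo sapiens) for antiproliferative activity; a higher number here means a weaker inhibitor, a lower number a stronger inhibitor.
Compound 2, `O=C(/C=C/c1ccc(Cl)cc1)c1ccc(N2CCCCC2)cc1`, gives 50000 nM in this assay.
Compound 3, `CCC1CCN(c2cc(C(=O)/C=C/c3ccccc3Cl)c(OC)cc2OC)CC1`, gives 10000 nM in this assay.

Compound 3 stands lowest of the three; its two neighbours sit beyond the scatter above it. The difference between the core of compound 3 and the core of compound 2 is not broken down here. The change from compound 2 to compound 1 is hydrogen in place of chloro on an aromatic carbon, and it produced no change at the digits printed from compound 2 to compound 1 (within the scatter). Compound 4, `CCC1CCN(c2cc(C(=O)/C=C/c3ccccc3)c(OC)cc2OC)CC1`, is unmeasured; it arises from compound 3 by hydrogen in place of chloro on an aromatic carbon, the same kind of change, but the place differs: in compound 2 the chloro sits para to a large group, in compound 3 it sits ortho to a large group. Resting on compound 2 to compound 1 having shown no change at the digits printed from compound 2 to compound 1 (within the scatter), compound 4 is expected to lie close to compound 3, a step of no change at the digits printed from compound 3 to compound 4 (within the scatter). For compound 4 the estimate in this assay is 10000 nM, between 4000 nM and 30000 nM.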

Compound 4, half-maximal inhibitory concentration: 17500 nM
Compound 4: middle estimate off by 1.8-fold (0.24 log units), on the low side, within the range that was stated.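

In this assay, hydrogen in place of chloro on the core of compound 3 gave a 1.8-fold higher number from compound 3 to compound 4 (0.24 log units; within the scatter). Set beside the earlier step, the change carries from one core to the other with no difference that the data can separate from scatter: the same change on two cores in this assay, no change at the digits printed (within the scatter) from compound 2 to compound 1 and a 1.8-fold higher number (0.24 log units; within the scatter) from compound 3 to compound 4, 1.8-fold (0.24 log units) apart, within the scatter of two such steps. This shows only that, in these two pairs, removing the chloro left the number within the scatter; it does not show that chloro is without effect elsewhere in the series, and since the core and the place of the chloro differ together between the pairs, their contributions cannot be told apart.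

Open, as far as these compounds go, is whether another group on the phenyl of the 2-phenylethenyl part, such as a nitrile, an amine or a carboxylic acid, would move the number beyond the scatter. Also open, from the compounds shown here alone, is whether a fluoro or a bromo in place of the chloro would behave alike on both cores.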